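Swapping benzyl for acetyl on a shared amine nitrogen

The source may hold more compounds than are shown below. What is called first, only, known or untested is meant among the compounds shown, and "the series" means these compounds.

Measured so far in a physicochemical assay for solubility, in phosphate buffer, at pH 7.1 (on this read-out lower numbers stand for lower solubility and higher numbers for higher solubility), are two compounds:
- Compound 1 (`COC(=O)C1CSC(c2ccccc2O)=N1`) gives 50000 nM
- Compound 2 (`O=C(NCCCCN(CCCCNC(=O)C1CSC(c2ccccc2O)=N1)Cc1ccccc1)C1CSC(c2ccccc2O)=N1`) gives 15000 nM

Of these two numbers, compound 2 at 15000 nM has the lower one, and its gap to compound 1 lies beyond the usual scatter of repeated measurements. The next compound keeps most of compound 2 and changes a single place. Compound 3 (`CC(=O)N(CCCCNC(=O)C1CSC(c2ccccc2O)=N1)CCCCNC(=O)C1CSC(c2ccccc2O)=N1`) carries acetyl in place of benzyl on an amine nitrogen and its measurement in this assay is still to come.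

Among the measured compounds shown here, no two measured compounds differ in one place only, so the data hold no direct precedent for this swap and any forecast must stay cautious. The expected change is upward, with a 2.3-fold higher number from compound 2 to compound 3 (0.37 log units; beyond the scatter) as an estimate, only just beyond the scatter. For the measured compounds named here, compound 1 at 50000 nM holds the only higher number so far, so the estimate is kept near that level. The estimate for compound 3 is 35000 nM with an expected range between 14000 nM and 80000 nM on the same scale.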

Compound 3, solubility: 10000 nM
For compound 3 the middle estimate is 3.5-fold (0.54 log units) above the measured one; the measured number lies below the stated range.
By their numbers in this assay, from the lowest: compounds 3 and 2 (each within the scatter of the next); then compound 1.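

Replacing benzyl with acetyl on an amine nitrogen whose other neighbours are saturated chain carbons gives a 1.5-fold lower number from compound 2 to compound 3 (0.18 log units; within the scatter) in this assay, so compound 2 and compound 3 cannot be told apart on this read-out. Among the compounds shown here, this is the first direct comparison at this position: benzyl, with 7 heavy atoms and a six-membered aromatic ring, leaves, and acetyl, with 3 heavy atoms, no ring and 1 hydrogen-bond acceptor, enters, yet the result stays within the normal spread of repeat measurements. The data shown offer no independent measurement that could explain why the two compounds read alike.

For the compounds shown here, this single pair shows only that these two groups give similar readings in this one setting, and it cannot establish a general rule for the position. It leaves open how a different group on the same nitrogen would read in this assay, for example a carboxylic acid on a short chain, a longer chain of saturated carbons, or a plain hydrogen that would leave a simple amine there.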